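Removing One Nitrile from a Dinitrile Thioether

The compounds below may be only part of what the source reports. "The series", "measured", "known", "first", "only" and "open" are said of these compounds alone.

The series shares a dinitrile thioether core, with compound 1 `N#Cc1ccc(Sc2ccc(Br)cc2)cc1C#N`, compound 2 `N#Cc1ccc(SCCc2ccccc2)cc1C#N` and compound 3 `CC(C)CCSc1ccc(C#N)c(C#N)c1` measured in an assay on microsomes for inhibition of Amine oxidase [flavin-containing] A (Homo sapiens), read by fluorescence and spectrophotometry, with a stated time of 20 min; a higher number here means a weaker inhibitor, a lower number a stronger inhibitor. Compound 1 gives 19000 nM, compound 2 gives 7190 nM and compound 3 gives 1450 nM. Compound 2 thus stands second highest of the three numbers, with compound 1 above it and compound 3 below it. For the measured compounds named here, the one measured step, a 5.0-fold lower number from compound 2 to compound 3 (0.70 log units; beyond the scatter), changes the chain on the sulfur and leaves both nitriles in place. Going by the values given here, compound 4 `N#Cc1ccc(SCCc2ccccc2)cc1` instead differs from compound 2 by hydrogen in place of cyano on an aromatic carbon, so no measured step bears on this change; every measured compound keeps both nitriles. Among the compounds with values here, with no precedent, the step from compound 2 to compound 4 is estimated to be a modest rise in the number, a 2.1-fold higher number from compound 2 to compound 4 (0.32 log units; beyond the scatter), reflecting only the general uncertainty. Compound 4 is therefore expected to give about 15000 nM in this assay, with a range of 4000 nM to 60000 nM.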

Compound 4, half-maximal inhibitory concentration: 54300 nM
Compound 4: middle estimate off by 3.6-fold (0.56 log units), on the low side; the measured number falls inside the stated range.
By their numbers in this assay, from the lowest: compound 3; then compound 2; then compound 1; then compound 4.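

In this assay, the cyano group on an aromatic carbon, ortho to a cyano group and meta to a group of 9 heavy atoms, proves to matter: hydrogen in its place brings a 7.6-fold higher number from compound 2 to compound 4 (0.88 log units; beyond the scatter). This is the first change shown on the shared core rather than on the chain on the sulfur, and in this single pair, keeping both nitriles goes with the lower number. Nothing measured here bears on why the number rises at this position.

The single-nitrile form is shown only with the chain of compound 2, so it remains open whether the same change would move compound 1 or compound 3 as far. Also open, going by these compounds, is how an amine, a carboxylic acid or an amide would compare with the cyano group at this position.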